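This account rests on a few compounds, and the source may have more. Where it says the series, first, only, none or still open, it means among the compounds named here.

In a functional assay on L1210 cells (Mus musculus) for antiproliferative activity, read by MTT assay, with a stated time of 72 h (a higher number here means a weaker inhibitor, a lower number a stronger inhibitor), compound 1 (`COc1ccc(C2OC(c3cc(OC)c(OC)c(OC)c3)=NN2C(C)=O)cc1`) gives 57000 nM. Compound 2 (`COc1ccccc1C1OC(c2cc(OC)c(OC)c(OC)c2)=NN1C(C)=O`) gives 48000 nM, within the scatter of compound 1. Compound 3 (`COc1cc(C2=NN(C(C)=O)C(c3cc(OC)c(OC)c(OC)c3)O2)cc(OC)c1OC`) reads > 100000 nM, which is a limit of the assay and not a number.

Compound 4 (`COc1cc(C2=NN(C(C)=O)C(c3ccccc3)O2)cc(OC)c1OC`) carries one change from compound 1: hydrogen in place of methoxy on an aromatic carbon, or 4-methoxyphenyl to phenyl. Among the compounds with values here, only one measured step touches this group, a 1.2-fold lower number from compound 1 to compound 2 (0.07 log units; within the scatter), and it moves the methoxy rather than removing it. No step beyond the scatter is therefore expected in this assay, and no direction is favoured. The estimated step is a 1.1-fold higher number from compound 1 to compound 4 (0.02 log units; within the scatter). For compound 4 the expected value is 60000 nM, with an estimated range of 28000 nM to 100000 nM.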

Compound 4, half-maximal inhibitory concentration: 6400 nM
Beside the measured number, compound 4's estimate is 9.4-fold (0.97 log units) above it; the whole stated range lies above it.
By their numbers in this assay, from the lowest: compound 4; then compounds 2 and 1 (each within the scatter of the next). At a limit, above all of these: compound 3.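

In this assay, within the data shown here, removing the methoxy from the phenyl ring gives the first measured change beyond the scatter: an 8.9-fold lower number from compound 1 to compound 4 (0.95 log units; beyond the scatter) and, from the ortho-substituted isomer's counterpart, a 7.5-fold lower number from compound 2 to compound 4 (0.88 log units; beyond the scatter) in the same direction. Moving the methoxy left the number within the scatter, whereas removing it does not, so among these compounds its presence matters more than its placement. Nothing shown accounts for this step.

Open, from the compounds shown here alone, is whether the gain belongs to hydrogen alone or would persist with a fluorine, a hydroxyl or an amine at that position. Compound 3 stands at a limit, not a number, so it gives no size for further methoxy groups on this ring.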